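Methylsulfonyl for methylsulfanyl on two triazole cores

A few compounds are considered here, and "the series" means these few. Any claim that something is new, unique, unknown or untested is made for them only; others in the source may bear on it.

Compound 1 `CSc1nnc(-c2cccc3ccccc23)n1C`: in a functional assay on the whole organism for antagonist activity, with Mus musculus as the target (a lower number here means that less compound is needed, a higher number that more compound is needed for the effect), compound 1 gives only a limit, > 200 mg/kg.
Compound 2 `Cn1c(-c2cccc3ccccc23)nnc1S(C)(=O)=O`: in this assay compound 2 gives only a limit, > 200 mg/kg.
Compound 3 `CSc1nc(-c2ccc(Cl)cc2)nn1C`: in this assay compound 3 gives only a limit, > 200 mg/kg.

All three measured values sit at the limit of > 200 mg/kg in this assay, at which 3 of the 3 values shown sit. The step that the two limits leave unreadable from compound 1 to compound 2 corresponds to the change (methylsulfonyl in place of methylsulfanyl on an aromatic carbon); its size cannot be read because both ends are limits.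

Compound 4 `Cn1nc(-c2ccc(Cl)cc2)nc1S(C)(=O)=O` is not yet measured. It arises from compound 3 by methylsulfonyl in place of methylsulfanyl on an aromatic carbon. This is the same kind of change as from compound 1 to compound 2, with one difference around the place: in compound 3 the ring atom two ring bonds away bears a group of 7 heavy atoms, whereas in compound 1 it bears a large group. How the core of compound 1 differs from the core of compound 3 is not broken down here.

For compound 4 the step that the limit leaves unreadable from compound 3 to compound 4 is expected to be small, resting on the limit of > 200 mg/kg in this assay, at which 3 of the 3 values shown sit, and on the unreadable step that the two limits leave unreadable from compound 1 to compound 2. Compound 4 is estimated at 300 mg/kg, with an expected range from 150 mg/kg to 1000 mg/kg. Compound 4 is expected to remain at the limit in this assay.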

Compound 4, dose for half-maximal effect: > 200 mg/kg
Compound 4: no number, only a limit (the forecaster's own chance of this, stated with the estimate: 85%); the middle value does not contradict the limit.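

In this assay compound 4 gives only a limit, > 200 mg/kg, so no size can be read for the step from compound 3 to compound 4. All values shown stand at one reading: the limit of > 200 mg/kg in this assay, at which 4 of the 4 values shown sit.

The compounds shown leave open whether methylsulfonyl in place of methylsulfanyl on an aromatic carbon shifts the dose for half-maximal effect on either core.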